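Replacing One Side Group on a Shared Core

The compounds below may be only part of what the source reports. "The series", "measured", "known", "first", "only" and "open" are said of these compounds alone.

- compound 1 `CS(=O)(=O)Nc1ccc(-n2cc(OCc3ccccc3)nn2)cc1Oc1ccccc1` gives 12300 nM
- compound 2 `Cc1cc(OCc2cn(-c3ccc(NS(C)(=O)=O)c(Oc4ccccc4)c3)nn2)ccc1Cl` gives 9800 nM

Among the measured compounds shown here, in a functional assay on HepG2 cells (Homo sapiens) for inhibition, read by MTT assay, with a stated time of 48 h (a higher number here means a weaker inhibitor, a lower number a stronger inhibitor), compound 2 (9800 nM) cannot be told apart from compound 1 (12300 nM), the only other compound measured so far. Compound 3 `Cc1ccc(-c2cn(-c3ccc(NS(C)(=O)=O)c(Oc4ccccc4)c3)nn2)cc1` brings a new change 4-methylphenyl in place of (4-chloro-3-methylphenoxy)methyl on an aromatic carbon with 4-methylphenyl in place of (4-chloro-3-methylphenoxy)methyl on an aromatic carbon. For the measured compounds named here, only one measured step bears on this place (a 1.3-fold lower number from compound 1 to compound 2 (0.10 log units; within the scatter)), and it stayed within the scatter. One step is thin evidence, so no shift beyond the scatter is expected in either direction. The estimated step is small (a 1.0-fold higher number from compound 2 to compound 3 (0.01 log units; within the scatter)). Compound 3 is estimated at 10000 nM (expected range 4000 nM to 25000 nM).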

Compound 3, half-maximal inhibitory concentration: 18300 nM
Compound 3: the middle estimate sits 1.8-fold (0.26 log units) below what was measured; low and high end bracket the measured number.
By their numbers in this assay, from the lowest: compounds 2, 1 and 3 (each within the scatter of the next).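

In this assay, placing 4-methylphenyl on this aromatic carbon gives a 1.9-fold higher number from compound 2 to compound 3 (0.27 log units; within the scatter) and, against benzyloxy, a 1.5-fold higher number from compound 1 to compound 3 (0.17 log units; within the scatter). A group with no oxygen, attached straight through its ring, therefore cannot be told apart from the two oxygen-bearing groups. No measurement shown explains these readings. All three groups carry a six-membered aromatic ring of carbon only. As far as these compounds go, whether an amine or a carboxylic acid at this position would shift the number beyond the scatter remains open.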